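This account rests on a few compounds, and the source may have more. Where it says the series, first, only, none or still open, it means among the compounds named here.

Of the compounds shown here, three built on a shared core have been measured in a functional assay on SK-OV-3 cells (Homo sapiens) for antiproliferative activity, read by MTT assay, with a stated time of 24 h; on this read-out higher numbers stand for weaker inhibition and lower numbers for stronger inhibition. Compound 1 `COc1ccc(C(=O)/C=C/c2ccc(N(c3ccccc3)c3ccccc3)cc2)c2c1C=CC(C)(C)O2` returns only a limit of the assay, > 10000 nM, rather than a number. Compound 2 `COc1ccc(C(=O)/C=C/c2ccc(-n3ccnc3)cc2)c2c1C=CC(C)(C)O2` gives 7200 nM. Compound 3 `COc1ccc(C(=O)/C=C/c2ccc([N+](=O)[O-])cc2)c2c1C=CC(C)(C)O2` gives 3420 nM, the lowest of the two real numbers, with compound 2 as its nearest neighbour. Among the compounds with values here, the only single-change step among the measured compounds is a 2.1-fold lower number from compound 2 to compound 3 (0.32 log units; beyond the scatter), so the number moved beyond the usual scatter when one aromatic substituent was exchanged for another.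

Compound 4 `COc1ccc(C(=O)/C=C/c2cccc(O)c2)c2c1C=CC(C)(C)O2` has not yet been measured. It differs from compound 3 by 3-hydroxyphenyl in place of 4-nitrophenyl on a double-bonded chain carbon bound to a double-bonded chain carbon. Within the data shown here, no measured step exchanges a group at this position for a hydroxyphenyl, so the one step available serves only as a loose guide to how far the number might move. Compound 4 is therefore expected to land close to its neighbour, the estimated step being a 1.0-fold higher number from compound 3 to compound 4 (0.01 log units; within the scatter). For compound 4 in this assay the estimate is 3500 nM, expected to fall between 1200 nM and 10000 nM.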

Compound 4, half-maximal inhibitory concentration: > 10000 nM
Compound 4: a limit, no number; the forecaster's own chance of this, stated with the estimate: 15%; at least 2.8-fold (0.45 log units) between middle value and limit.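

In this assay, compound 4 gives > 10000 nM, which is a limit of the assay and not a number. Putting 3-hydroxyphenyl in place of 4-nitrophenyl on a double-bonded chain carbon bound to a double-bonded chain carbon gives an at least 2.9-fold higher number from compound 3 to compound 4 (0.46 log units; beyond the scatter), so the exchange at this place moves the number beyond the scatter, towards weaker inhibition. The earlier step linked two real numbers, whereas this one ends at the edge of what the assay reads, so its full size remains unknown: the limit of > 10000 nM in this assay, at which 2 of the 4 values shown sit.

The compounds shown cannot separate the effect of removing the nitro group from that of introducing the hydroxy group. As far as these compounds go, how an amine or a carboxylic acid in place of that hydroxy group would behave also remains open.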